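Lengthening the Alkyl Arm Beside the Hydroxyurea

The source may report more compounds than this note shows. Statements on the series, on what has been measured and on what is new or still open speak of the compounds shown alone.

Of the compounds shown here, two have been measured in an assay for inhibition of Polyunsaturated fatty acid 5-lipoxygenase (Homo sapiens), read by HPLC, with stated times of 15 min and 10 min; a lower number here means a stronger inhibitor, a higher number a weaker inhibitor. Compound 1 `CC(C)C(C#Cc1cccc(C(=O)NCc2ccccc2C(F)(F)F)c1)N(O)C(N)=O` gives 500 nM in this assay, the higher of the two numbers recorded. Compound 2 `C[C@H](C#Cc1cccc(C(=O)NCCC(c2ccccc2)c2ccc(Cl)c(Cl)c2)c1)N(O)C(N)=O` gives 96 nM in this assay, and the two values lie apart by more than the usual scatter; since these two structures differ in several places at once, no single step can be read between them. Compound 3 `CC(C)CC(C#Cc1cccc(C(=O)NCc2ccccc2C(F)(F)F)c1)N(O)C(N)=O` has not yet been measured. It differs from compound 1 in one place only: isobutyl in place of isopropyl on a saturated chain carbon bound to an amide-type nitrogen and a triple-bonded carbon. Among the measured compounds shown here, no pair of measured compounds isolates a change of this kind, so the expectation rests on compound 1 alone. Such a modest extension of the saturated chain is expected to move the number little, in no direction beyond the scatter. Compound 3 is therefore estimated at 450 nM, with a range from 150 nM to 1400 nM, an expected step of a 1.1-fold lower number from compound 1 to compound 3 (0.05 log units; within the scatter).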

Compound 3, half-maximal inhibitory concentration: 600 nM
Compound 3: the middle estimate sits 1.3-fold (0.12 log units) below what was measured, within the range that was stated.
By their numbers in this assay, from the lowest: compound 2; then compounds 1 and 3 (each within the scatter of the next).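

Among the compounds shown here, the step from isopropyl to isobutyl gives the first comparison in this set that isolates a single place: in this assay it amounts to a 1.2-fold higher number from compound 1 to compound 3 (0.08 log units; within the scatter). On the core of compound 1, this saturated chain carbon therefore carries either of these two branched alkyl groups with no difference that can be told from the scatter, so the added carbon registers no detectable effect here. Nothing measured here offers an explanation for this result.

The compounds shown leave open how a longer chain, such as n-hexyl, or a cyclohexyl or phenyl ring on this carbon would read. The methyl group that compound 2 carries on this carbon also cannot be compared with isopropyl or isobutyl, as compound 2 differs from compound 1 and compound 3 in several places at once.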